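A swap from phenyl to pyridin-3-yl without a measured parent

The compounds below may be only part of what the source reports. "The series", "measured", "known", "first", "only" and "open" are said of these compounds alone.

Among the measured compounds shown here, in an ADME assay on NIH3T3 cells (Mus musculus) for cytotoxicity, read by neutral red uptake, with a stated time of 24 h (a higher number here means a weaker inhibitor, a lower number a stronger inhibitor), compound 1 (`COc1c(-c2ccccc2)c2ccccc2n(Cc2ccc(C(=O)NO)cc2)c1=O`) gives 90000 nM and that is the only number available so far. Compound 2 (`CCN(CC)Cc1ccc(Cn2c(=O)c(OCc3ccc(C(=O)NO)cc3)c(-c3ccccc3)c3ccccc32)cc1`) has no place on this scale: compound 2 stands as "not determined" (no result reported), so it offers no starting value. Compound 3 (`CCN(CC)Cc1ccc(Cn2c(=O)c(OCc3ccc(C(=O)NO)cc3)c(-c3cccnc3)c3ccccc32)cc1`) differs from compound 2 in one place, with pyridin-3-yl in place of phenyl on an aromatic carbon. For the measured compounds named here, no measured step shows what this swap does here. Even so, no change beyond the usual scatter is expected between these two in this assay in either direction. The structures of compound 1 and compound 3 differ in more than this one place, so compound 1 at 90000 nM is only a loose guide. For compound 3 the expected value is 30000 nM with an estimated range from 4000 nM to 150000 nM as a deliberately wide span.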

Compound 3, half-maximal inhibitory concentration: 90000 nM
For compound 3 the middle estimate is 3.0-fold (0.48 log units) below the measured one, within the range that was stated.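

Compound 2 offers no number to set against compound 3, so no step can be read from the swap of phenyl for pyridin-3-yl. On these data alone, what that swap does to this read-out stays open, and no other data here bear on the result.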